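This account rests on a few compounds, and the source may have more. Where it says the series, first, only, none or still open, it means among the compounds named here.

Working notes on the series.

Compound 3 `Clc1ccc(-c2noc(-c3cc4ccccc4[nH]3)n2)cc1` closes the measured trio. In a functional assay on MCF7 cells (Homo sapiens) for antiproliferative activity, read by WST assay, with a stated time of 72 h (a lower number here means a stronger inhibitor, a higher number a weaker inhibitor), compound 3 gives > 50000 nM, a limit of the assay and not a number. Compound 1 `Cc1noc(-c2cc3ccccc3[nH]2)n1` also reaches only a limit: in this assay compound 1 gives > 50000 nM. Within the data shown here, compound 2 `c1ccc(-c2noc(-c3cc4ccccc4[nH]3)n2)cc1` is the one member with a number, giving 45700 nM in this assay. Two of the three values sit at the same ceiling (the limit of > 50000 nM in this assay, at which 2 of the 3 values shown sit).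

The next change is amino in place of 4-chlorophenyl on an aromatic carbon, giving compound 4 `Nc1noc(-c2cc3ccccc3[nH]2)n1`. The steps recorded so far bear on it only loosely: an at least 1.0-fold lower number from compound 1 to compound 2 (0.03 log units; that floor lies within the scatter) and an at least 1.0-fold higher number from compound 2 to compound 3 (0.03 log units; that floor lies within the scatter) both lie within the scatter, and a step that the two limits leave unreadable from compound 1 to compound 3 cannot be read between two limits. Every substituent tried at this carbon of the shared core so far has left this assay near or beyond its ceiling, so no step beyond the scatter is expected from the amino group either.

Compound 4 is therefore expected to give about 50000 nM in this assay, within 20000 nM to 120000 nM, most likely again as a limit. That estimate means a number no higher from compound 3 to compound 4 (the limit leaves the size open), which is not expected to be readable.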

Compound 4, half-maximal inhibitory concentration: > 50000 nM
Compound 4 ended at the assay's limit; the forecaster's own chance of this, stated with the estimate: 70%; the middle value lies on the limit itself.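

The new information at this carbon, which lies between two ring nitrogen atoms, is that a group with no ring and with a hydrogen-bond donor does not bring this assay below its ceiling any more than the ring-bearing groups did. Among these compounds, the one readable step is an at least 1.0-fold higher number from compound 2 to compound 4 (0.03 log units; that floor lies within the scatter), while the steps to compound 4 from compound 1 and from compound 3 cannot be read, as each joins two limits. Compound 2 remains the only member with a number, and the ceiling now holds most of the series: the limit of > 50000 nM in this assay, at which 3 of the 4 values shown sit.

Going by these compounds, whether a carboxylic acid or a longer alkyl chain at this carbon would give a value clear of the ceiling stays open. So does whether a methoxy or hydroxyl group on the phenyl ring of compound 2 would give a step beyond the scatter.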